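Replacing the basic piperazine on the shared core with methylamino

The compounds below may be only part of what the source reports. "The series", "measured", "known", "first", "only" and "open" are said of these compounds alone.

Among the compounds with values here, compound 1 `CN1CCN(c2cc(CN3C(=O)N(c4ccc(SC(F)(F)F)cc4)C(=O)C3(C)C)ccn2)CC1` is the only member of this small set with a number rather than a limit: in a physicochemical assay for solubility, read by nephelometry (a higher number here means a more soluble compound, a lower number a less soluble compound), compound 1 gives 0.159 ug/mL. Compound 2 `CN(C)c1cc(CN2C(=O)N(c3ccc(SC(F)(F)F)cc3)C(=O)C2(C)C)ccn1` reaches only a limit, as compound 2 in this assay gives < 0.022 ug/mL (the limit of < 0.022 ug/mL in this assay, at which 1 of the 3 values shown sits). Compound 3 `CNC(=O)c1cc(CN2C(=O)N(c3ccc(SC(F)(F)F)cc3)C(=O)C2(C)C)ccn1` likewise sits at a limit, since compound 3 in this assay gives < 0.023 ug/mL (the limit of < 0.023 ug/mL in this assay, at which 1 of the 3 values shown sits). Compound 4 `CNc1cc(CN2C(=O)N(c3ccc(SC(F)(F)F)cc3)C(=O)C2(C)C)ccn1` has not yet been measured; it differs from compound 1 by methylamino in place of 4-methylpiperazin-1-yl on an aromatic carbon.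

The two measured steps that bear on this change both start at compound 1 and both fall: an at least 7.2-fold lower number from compound 1 to compound 2 (0.85 log units; beyond the scatter) and an at least 6.9-fold lower number from compound 1 to compound 3 (0.83 log units; beyond the scatter). Dimethylamino is the nearest relative of methylamino among them, so a drop of comparable size, down to the limit, is expected; the step of a 5.3-fold lower number from compound 1 to compound 4 (0.72 log units; beyond the scatter) is the estimate. Compound 4 is therefore expected to give about 0.03 ug/mL, within a range of 0.01 ug/mL to 0.1 ug/mL.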

Compound 4, solubility: 0.075 ug/mL
For compound 4 the middle estimate is 2.5-fold (0.40 log units) below the measured one; the measured number falls inside the stated range.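

In this assay, methylamino in place of 4-methylpiperazin-1-yl gives a 2.1-fold lower number from compound 1 to compound 4 (0.33 log units; beyond the scatter), so at this position, on an aromatic carbon next to the ring nitrogen, a group without the ring still leaves a readable number. The one methyl on the nitrogen also counts, with hydrogen in its place giving an at least 3.4-fold higher number from compound 2 to compound 4 (0.53 log units; beyond the scatter), while the exchange of methylcarbamoyl for methylamino gives an at least 3.2-fold higher number from compound 3 to compound 4 (0.51 log units; beyond the scatter). Both of these steps are only floors: compound 2 and compound 3 each stand at a limit of the assay, not at a number.

Going by these compounds, whether an unsubstituted amine, a longer chain such as ethylamino, or a morpholine ring would hold or raise the number here remains open. The compounds shown also do not separate the part played by the ring of 4-methylpiperazin-1-yl from that of its second nitrogen.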